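Swapping Nitro for Dimethylamino on a Shared Amidine Core

The compounds below may be only part of what the source reports. "The series", "measured", "known", "first", "only" and "open" are said of these compounds alone.

Compound 2, `O=[N+]([O-])c1cccc(C2=NC(c3ccc(F)cc3)(c3ccc(F)cc3)CN2)c1`: 4.3 nM
Compound 1, `Fc1ccc(C2(c3ccc(F)cc3)CNC(c3ccc(C(F)(F)F)cc3)=N2)cc1`: 160 nM

In an assay on LM cells for displacement of a labelled ligand from Neuropeptide Y receptor type 5 (Homo sapiens) (on this read-out lower numbers stand for stronger inhibition and higher numbers for weaker inhibition), compound 2 gives 4.3 nM, the lowest of the two numbers; compound 1 gives 160 nM, a gap well beyond the scatter. Compound 3, `CN(C)c1cccc(C2=NC(c3ccc(F)cc3)(c3ccc(F)cc3)CN2)c1`, differs from compound 2 only by dimethylamino in place of nitro on an aromatic carbon. Going by the values given here, no measured pair shows this particular change, so its effect is not known from these data. The expectation for compound 3 is a moderate loss of potency, a step of a 7.0-fold higher number from compound 2 to compound 3 (0.84 log units; beyond the scatter) beyond the scatter. Compound 3 is estimated at 30 nM, with a range from 8 nM to 120 nM.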

Compound 3, half-maximal inhibitory concentration: > 1000 nM
Compound 3: only a limit was reported; the forecaster's own chance of this, stated with the estimate: 2%; middle value at least 33-fold (1.52 log units) from the limit.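

Exchanging nitro for dimethylamino on this aromatic carbon, meta to a large group, is far from a neutral swap: it produces an at least 230-fold higher number from compound 2 to compound 3 (2.36 log units; beyond the scatter). Going by these compounds alone, the earlier compounds held no pair with this change, so this is the first sign that the shared core does not tolerate every group here. The value of compound 3 is a limit, not a number: the limit of > 1000 nM in this assay, at which 1 of the 3 values shown sits.

What lies behind the loss stays open. A simple amine or a nitrile at the same place would show whether the loss follows dimethylamino itself or the absence of nitro.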